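Tetrazole spacing in a hydroxyacetophenone leukotriene series

The compounds below may be only part of what the source reports. "The series", "measured", "known", "first", "only" and "open" are said of these compounds alone.

Two compounds of this set have numbers. Compound 1 `CCCc1c(CSc2ccc(-c3nn[nH]n3)cc2)ccc(C(C)=O)c1O` gives 20 nM in a functional assay on ileum (Cavia porcellus) for inhibition of cysteinyl leukotriene receptor (Homo sapiens); a lower number here means a stronger inhibitor, a higher number a weaker inhibitor. Compound 2 `CCCc1c(COCCOc2ccc(-c3nn[nH]n3)cc2)ccc(C(C)=O)c1O` gives 50.1 nM in this assay, the higher of the two numbers, and the gap to compound 1 lies beyond the usual scatter. Going by the values given here, no single-point step between measured compounds is available.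

Compound 3 `CCCc1c(COCCOc2ccc(Cc3nnn[nH]3)cc2)ccc(C(C)=O)c1O` is the next entry. It differs from compound 2 by (1H-tetrazol-5-yl)methyl in place of 2H-tetrazol-5-yl on an aromatic carbon, so the acidic ring is carried one carbon further from the aryl ring while the donor and acceptor count is unchanged. Among the compounds with values here, no earlier pair tells how this spacing is tolerated. A modest move toward a higher number is expected for compound 3, with a 3.0-fold higher number from compound 2 to compound 3 (0.48 log units; beyond the scatter) in this assay. Compound 3 is estimated at 150 nM, within a range from 40 nM to 600 nM.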

Compound 3, half-maximal inhibitory concentration: 100 nM
Estimate against measurement, compound 3: 1.5-fold (0.18 log units) above, within the range that was stated.
By their numbers in this assay, from the lowest: compound 1; then compounds 2 and 3 (each within the scatter of the next).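

In this assay, (1H-tetrazol-5-yl)methyl in place of 2H-tetrazol-5-yl on this aromatic carbon gives a 2.0-fold higher number from compound 2 to compound 3 (0.30 log units; within the scatter), so the extra carbon leaves a difference that cannot be told apart from repeat measurements. Earlier compounds gave no reading of this spacing; this pair shows that, on the chain of compound 2, the tetrazole need not be attached directly to the six-membered aromatic ring for the number to stay within the scatter. Nothing available offers an explanation for this result.

Still open, going by these compounds, is what a carboxylic acid in place of the tetrazole, or a longer chain carrying the tetrazole, would give at this position. Also open, on these data alone, is whether (1H-tetrazol-5-yl)methyl would be tolerated equally on the sulfur-linked chain of compound 1.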